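The source may report more compounds than this note shows. Statements on the series, on what has been measured and on what is new or still open speak of the compounds shown alone.

Working notes on the series. For the measured compounds named here, in an ADME assay on MT4 cells (Homo sapiens) for cytotoxicity, read by MTT assay (on this read-out higher numbers stand for lower toxicity in this test and lower numbers for higher toxicity in this test), compound 1 (`Cc1ccc(CC2C(=O)N(O)C(=O)c3ccccc32)cc1`) gives 5500 nM, the lowest of the three numbers available so far. Compound 2 (`CCCCC1C(=O)N(O)C(=O)c2ccccc21`) gives 25400 nM, and compound 3 (`O=c1c2ccccc2c(Cc2ccccc2)c(O)n1O`) gives 88000 nM.

Still unmeasured is compound 4 (`O=C1c2ccccc2C(CCc2ccccc2)C(=O)N1O`), which has the same atoms as compound 1, joined differently: benzyl in place of 4-methylphenyl on a saturated chain carbon bound to a saturated ring carbon. In words, this is benzyl in place of 4-methylphenyl on a saturated chain carbon bound to a saturated ring carbon.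

Going by the values given here, only one measured step bears on this place: a 4.6-fold higher number from compound 1 to compound 2 (0.66 log units; beyond the scatter), with propyl in place of 4-methylphenyl. That step was modest, though beyond the scatter, and it took away the aromatic ring, whereas compound 4 keeps one. Among the compounds with values here, no measured step connects compound 3 to the others, so it sets no size here. A single step is thin support, but a change in the same direction as that step and smaller in size seems the reasonable expectation. The expected step is a 1.8-fold higher number from compound 1 to compound 4 (0.26 log units; within the scatter), so no clear shift beyond the scatter is firmly expected. For compound 4 the estimated value is 10000 nM, with an expected range of 3500 nM to 35000 nM.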

Compound 4, half-maximal cytotoxic concentration: 30000 nM
Compound 4: middle estimate off by 3.0-fold (0.48 log units), on the low side, within the range that was stated.
By their numbers in this assay, from the lowest: compound 1; then compounds 2 and 4 (each within the scatter of the next); then compound 3.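

In this assay, benzyl in place of 4-methylphenyl on a saturated chain carbon bound to a saturated ring carbon gives a 5.5-fold higher number from compound 1 to compound 4 (0.74 log units; beyond the scatter), so keeping an aromatic ring in the substituent does not by itself keep the number at the level of compound 1. The second new step, a 1.2-fold higher number from compound 2 to compound 4 (0.07 log units; within the scatter), with phenyl in place of ethyl on a saturated chain carbon, two bonds along the chain from a saturated ring carbon, lies within the scatter, so at that place the terminal phenyl and the terminal ethyl cannot be told apart in this test, and compound 1 alone stands apart among the three compounds that share this core. No available evidence accounts for either step.

From the compounds shown here alone, it stays open whether the low number of compound 1 goes with the methyl group or with the 4-methylphenyl arrangement as a whole, a question that a plain phenyl at the same place would bear on. Going by these compounds, what an amine, a carboxylic acid or a longer chain would give at this place also remains open, as does any single-place link between compound 3 and the rest of the series.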